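Swapping One Alkylphenyl Group for Another

The source may report more compounds than this note shows. Statements on the series, on what has been measured and on what is new or still open speak of the compounds shown alone.

compound 1 `COc1cccc(CNc2nc(Nc3ccc(N4CCN(C)CC4)cn3)ncc2Cl)c1` gives 20300 nM
compound 2 `CCc1ccc(Nc2nc(Nc3ccc(N4CCN(C)CC4)cn3)ncc2Cl)cc1` gives 5560 nM

In a functional assay on MDA-MB-231 cells (Homo sapiens) for inhibition, read by CCK-8 assay, with a stated time of 48 h (on this read-out higher numbers stand for weaker inhibition of growth and lower numbers for stronger inhibition of growth), compound 2 has the lower of the two numbers (5560 nM). Compound 3 `CC(C)c1cccc(Nc2nc(Nc3ccc(N4CCN(C)CC4)cn3)ncc2Cl)c1` makes one change (3-isopropylphenyl in place of 4-ethylphenyl on a nitrogen on an aromatic ring), with 3-isopropylphenyl in place of 4-ethylphenyl on a nitrogen on an aromatic ring. Going by the values given here, the only measured step at this place (a 3.7-fold lower number from compound 1 to compound 2 (0.56 log units; beyond the scatter)) was modest and replaced 3-methoxybenzyl with 4-ethylphenyl. The new change only exchanges one carbon-only aromatic group for another, so no shift beyond the scatter is expected in this assay. The expected step (a 1.2-fold lower number from compound 2 to compound 3 (0.09 log units; within the scatter)) is small and slightly downward. Compound 3 is estimated at 4500 nM (range 1700 nM to 12000 nM).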

Compound 3, concentration for 50% growth inhibition: 5590 nM
The estimate for compound 3 lay 1.2-fold (0.09 log units) below the measured number; low and high end bracket the measured number.
By their numbers in this assay, from the lowest: compounds 2 and 3 (each within the scatter of the next); then compound 1.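

In this assay, 3-isopropylphenyl in place of 4-ethylphenyl gives a 1.0-fold higher number from compound 2 to compound 3 (0.00 log units; within the scatter) on this nitrogen, so these two carbon-only aromatic groups cannot be told apart here. The other new comparison, a 3.6-fold lower number from compound 1 to compound 3 (0.56 log units; beyond the scatter), shows that compound 3, like compound 2, sits apart from the 3-methoxybenzyl compound. No independent evidence explains these numbers. Still open, from the compounds shown here alone, is whether a phenyl ring carrying an amine or a carboxylic acid at this place would shift the number, and whether any group here can take it well beyond compound 2 and compound 3.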